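The source may report more compounds than this note shows. Statements on the series, on what has been measured and on what is new or still open speak of the compounds shown alone.

Working notes on the triketone series in an assay for inhibition of 4-hydroxyphenylpyruvate dioxygenase (Sus scrofa); a higher number here means a weaker inhibitor, a lower number a stronger inhibitor.

Of the compounds shown here, two have numbers so far. Compound 1 `CCC(=O)C1C(=O)CCCC1=O` gives 17800 nM in this assay. Compound 2 `O=C1CCCC(=O)C1C(=O)C1CC1` gives 6000 nM in this assay. Going by the values given here, the single step between them, cyclopropyl in place of ethyl on a carbonyl carbon, gave a 3.0-fold lower number from compound 1 to compound 2 (0.47 log units; beyond the scatter). Among the compounds with values here, on these two numbers compound 2 stands lowest, with compound 1 as its only neighbour.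

Compound 3 `CC(=O)C1C(=O)CCCC1=O` has not yet been measured. It differs from compound 2 in one place: methyl in place of cyclopropyl on a carbonyl carbon. Within the data shown here, the only step on record that bears on this change is the one from compound 1 to compound 2, which moved the number in this assay by a 3.0-fold lower number from compound 1 to compound 2 (0.47 log units; beyond the scatter) when the side group on that carbonyl carbon was enlarged. The present change goes the other way, to the smallest group in the series, so a step back towards higher numbers is expected, beyond the scatter and at least as large as that one. Compound 3 is therefore expected to give 30000 nM in this assay, within a range of 12000 nM to 80000 nM. That estimate corresponds to an expected step of a 5.0-fold higher number from compound 2 to compound 3 (0.70 log units; beyond the scatter).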

Compound 3, half-maximal inhibitory concentration: 11200 nM
Compound 3: middle estimate off by 2.7-fold (0.43 log units), on the high side; measured number outside the range, below it.
By their numbers in this assay, from the lowest: compounds 2, 3 and 1 (each within the scatter of the next, the first and the last beyond it).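

Replacing cyclopropyl with methyl on the carbonyl carbon gives a 1.9-fold higher number from compound 2 to compound 3 (0.27 log units; within the scatter) in this assay, so at this position methyl cannot be separated from cyclopropyl, although ethyl could be. Hydrogen in place of methyl on the saturated chain carbon bound to the carbonyl carbon gives a 1.6-fold lower number from compound 1 to compound 3 (0.20 log units; within the scatter) in this assay, so methyl and ethyl cannot be separated either, and a 3.0-fold lower number from compound 1 to compound 2 (0.47 log units; beyond the scatter) remains the only step beyond the scatter; the numbers therefore show no steady trend with the heavy-atom count of this side group, as compound 3, with the single carbon, lies within the scatter of both compound 1 and compound 2. No measurement at hand accounts for these numbers.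

Open, on these data alone, is whether a longer chain, an isopropyl or tert-butyl group, a cyclobutyl or cyclohexyl ring, or a phenyl ring on this carbonyl carbon would move the number well beyond the scatter of these three compounds. Also open, as far as these compounds go, is whether cyclopropyl keeps its edge over ethyl when the shared core carries another substituent, such as a methyl group or a fluorine atom.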